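The compounds below may be only part of what the source reports. "The series", "measured", "known", "first", "only" and "open" are said of these compounds alone.

Among the three measured compounds, compound 3 `O=C(COc1ccc2cc(/C=C3/SC(=O)NC3=O)ccc2c1)Nc1ccccc1` stands lowest in an assay on isolated protein for inhibition of histone deacetylase 4 (Homo sapiens), with a stated time of 1 h; a lower number here means a stronger inhibitor, a higher number a weaker inhibitor: compound 3 gives 2100 nM, while compound 2 `O=C(COc1ccc2cc(/C=C3/SC(=O)NC3=O)ccc2c1)Nc1ccc(F)cc1F` gives 3900 nM and compound 1 `O=C(COc1ccc2cc(/C=C3/SC(=O)NC3=O)ccc2c1)Nc1ccccn1` gives 17000 nM. The two gaps read a 1.9-fold lower number from compound 2 to compound 3 (0.27 log units; within the scatter) and an 8.1-fold lower number from compound 1 to compound 3 (0.91 log units; beyond the scatter). Compound 4 `O=C(COc1ccc2cc(/C=C3/SC(=O)NC3=O)ccc2c1)Nc1cccc(C(F)(F)F)c1` introduces (trifluoromethyl in place of hydrogen on an aromatic carbon). For the measured compounds named here, no measured step puts a trifluoromethyl on the phenyl; the nearest guide is a 1.9-fold lower number from compound 2 to compound 3 (0.27 log units; within the scatter), where fluorine substituents on the phenyl moved nothing beyond the scatter, whereas a 4.4-fold lower number from compound 1 to compound 2 (0.64 log units; beyond the scatter) came from exchanging the whole aryl group. A step in this assay within or near the scatter is therefore expected, direction uncertain. Compound 4 is estimated at 2500 nM, with a range of 800 nM to 8000 nM. This expectation corresponds to a 1.2-fold higher number from compound 3 to compound 4 (0.08 log units; within the scatter).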

Compound 4, half-maximal inhibitory concentration: 2500 nM
Compound 4: the middle estimate sits on the measured number at the digits printed, within the range that was stated.
By their numbers in this assay, from the lowest: compounds 3, 4 and 2 (each within the scatter of the next); then compound 1.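

In this assay, putting trifluoromethyl on this aromatic carbon of the phenyl adds four heavy atoms yet gives a 1.2-fold higher number from compound 3 to compound 4 (0.08 log units; within the scatter) and so leaves the number within the scatter. The larger substituent also gives a 1.6-fold lower number from compound 2 to compound 4 (0.19 log units; within the scatter) against the difluorinated ring, while a 6.8-fold lower number from compound 1 to compound 4 (0.83 log units; beyond the scatter) keeps the pyridin-2-yl compound apart from this group of phenyl amides. No evidence is available to explain these results. Still open, on these data alone, is whether an amine or a carboxylic acid on this carbon would shift the number beyond the scatter. As far as these compounds go, whether trifluoromethyl on another carbon of the ring would do so also remains open.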